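The compounds below may be only part of what the source reports. "The series", "measured", "known", "first", "only" and "open" are said of these compounds alone.

Measured compounds:
compound 1, `COc1ccc(-c2nn(-c3ccccc3)cc2C(=O)/C=C\Nc2ccc(O)cc2)cc1`, gives 1980 nM in a functional assay on PC-3 cells (Homo sapiens) for antiproliferative activity, read by MTT assay, with a stated time of 48 h; on this read-out lower numbers stand for stronger inhibition and higher numbers for weaker inhibition
compound 2, `COc1ccc(N/C=C\C(=O)c2cn(-c3ccccc3)nc2-c2ccc(OC)cc2)cc1`, gives 13400 nM in this assay
compound 3, `COc1cc(-c2nn(-c3ccccc3)cc2C(=O)/C=C\Nc2ccc(O)cc2)cc(OC)c1OC`, gives 4600 nM in this assay

Compound 1 and compound 2 share one core and differ only by methyl in place of hydrogen on an oxygen on an aromatic ring. That change gave a 6.8-fold higher number from compound 1 to compound 2 (0.83 log units; beyond the scatter), a weakening of the antiproliferative effect. Compound 3 carries a different core, and the difference between the two cores is not broken down here; in this assay compound 3 stands between the other two, with a higher number than compound 1 and a lower number than compound 2.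

Compound 4, `COc1ccc(N/C=C\C(=O)c2cn(-c3ccccc3)nc2-c2cc(OC)c(OC)c(OC)c2)cc1`, has not yet been measured. It differs from compound 3 by methyl in place of hydrogen on an oxygen on an aromatic ring, the same kind of change as from compound 1 to compound 2, at a place described in the same words. Because the earlier change gave a 6.8-fold higher number from compound 1 to compound 2 (0.83 log units; beyond the scatter), a weakening of roughly the same size is expected for compound 4, and the step is estimated as a 6.1-fold higher number from compound 3 to compound 4 (0.78 log units; beyond the scatter). Compound 4 is therefore expected to give about 28000 nM in this assay, estimated to lie between 10000 nM and 80000 nM.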

Compound 4, half-maximal inhibitory concentration: 9600 nM
The estimate for compound 4 lay 2.9-fold (0.46 log units) above the measured number, and the stated range ends above it.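

In this assay, the same change, 4-hydroxyphenyl to 4-methoxyphenyl, again gave a higher number on the second core, with a 2.1-fold higher number from compound 3 to compound 4 (0.32 log units; beyond the scatter), so the direction of the step carried over from the core of compound 1 to the core of compound 3. Its size did not carry over, and the step cannot be treated as a fixed increment in this series: the same change on two cores in this assay, a 6.8-fold higher number (0.83 log units; beyond the scatter) from compound 1 to compound 2 and a 2.1-fold higher number (0.32 log units; beyond the scatter) from compound 3 to compound 4, 3.2-fold (0.51 log units) apart, beyond the scatter of two such steps The other new step, 3,4,5-trimethoxyphenyl in place of 4-methoxyphenyl, gave a 1.4-fold lower number from compound 2 to compound 4 (0.14 log units; within the scatter), so compound 2 and compound 4 cannot be told apart here, and two pairs show neither why the size differs nor how the change would behave on any further core.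

The compounds shown leave open whether a longer chain on that oxygen, such as ethoxy, or an amine or a carboxylic acid in place of the hydroxy group would follow the same direction. They also leave open whether the same steps would appear in any other cell line.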